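Amino to carboxy on the phenyl ring of a urea

The compounds below may be only part of what the source reports. "The series", "measured", "known", "first", "only" and "open" are said of these compounds alone.

For the measured compounds named here, compound 3 `CC(C)c1cccc(C(C)C)c1NC(=O)NCC1(c2ccc(N)cc2)CCCC1` gives 29 nM in an assay on microsomes for inhibition of acyl-CoA:cholesterol acyltransferase (Oryctolagus cuniculus) (a higher number here means a weaker inhibitor, a lower number a stronger inhibitor), and stands at the low end of the three numbers measured so far. Compound 1 `COc1ccc(C2(CNC(=O)Nc3c(C(C)C)cccc3C(C)C)CCCC2)cc1` gives 31 nM in this assay, and a 1.1-fold lower number from compound 1 to compound 3 (0.03 log units; within the scatter) lies within the scatter. Compound 2 `CC(C)c1cccc(C(C)C)c1NC(=O)NCC1(c2ccc(C(F)(F)F)cc2)CCCC1` gives 66 nM, and a 2.3-fold lower number from compound 2 to compound 3 (0.36 log units; beyond the scatter) is a modest step, as is a 2.1-fold higher number from compound 1 to compound 2 (0.33 log units; beyond the scatter). Compound 4 `CC(C)c1cccc(C(C)C)c1NC(=O)NCC1(c2ccc(C(=O)O)cc2)CCCC1` carries the change (carboxy in place of amino on an aromatic carbon), on an aromatic carbon para to a large group. Going by the values given here, no measured step brings in a carboxy group, so the three steps show only that swapping this group moves the number by modest amounts. The expected step is therefore a 4.1-fold higher number from compound 3 to compound 4 (0.62 log units; beyond the scatter), with a wide range. Compound 4 is estimated at 120 nM, between 35 nM and 500 nM.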

Compound 4, half-maximal inhibitory concentration: 3100 nM
Compound 4: middle estimate off by 26-fold (1.41 log units), on the low side; the measured number lies above the stated range.
By their numbers in this assay, from the lowest: compounds 3 and 1 (each within the scatter of the next); then compound 2; then compound 4.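

In this assay, for the compounds shown here, this aromatic carbon, para to a large group, had so far taken methoxy, trifluoromethyl and amino with modest steps at most, but carboxy breaks sharply from all three: there is a 110-fold higher number from compound 3 to compound 4 (2.03 log units; beyond the scatter) and a 100-fold higher number from compound 1 to compound 4 (2.00 log units; beyond the scatter) and a 47-fold higher number from compound 2 to compound 4 (1.67 log units; beyond the scatter) and each of these is large. The position is therefore not indifferent to what it carries. No measurement here accounts for the size of this jump.

Going by these compounds alone, it remains open whether a methyl ester or a primary amide at this carbon would stay near the earlier compounds or follow compound 4.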